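Removing One Methoxy Group and Cell Survival

The source may report more compounds than this note shows. Statements on the series, on what has been measured and on what is new or still open speak of the compounds shown alone.

Compound 1 `COc1ccc(/C=C/C(=O)c2ccc(OC)c(OC)c2)cc1` and compound 2 `COc1ccc(/C=C/C(=O)c2ccc(OC)c(OC)c2)cc1OC` share one core, while compound 3 `COc1ccc(CCCc2ccc(OC)c(OC)c2OC)c(O)c1` is built on another; the difference between the two cores is not broken down here. In an ADME assay on RAW264.7 cells (Mus musculus) for cytotoxicity, read by MTT assay, with a stated time of 24 h, tested at 10 ug/mL (on this read-out lower numbers stand for a stronger effect and higher numbers for a weaker effect at the one concentration tested), compound 1 gives 73.9%, compound 2 gives 60.4%, and compound 3 gives 36.7%, the lowest of the three. The change hydrogen in place of methoxy on an aromatic carbon made a step of a number 13.5 percentage points higher from compound 2 to compound 1 (beyond the scatter). Compound 4 `COc1ccc(CCCc2cccc(OC)c2OC)c(O)c1` is not yet measured and arises from compound 3 by hydrogen in place of methoxy on an aromatic carbon, the same kind of change, though here the place is ortho to a methoxy group, meta to a methoxy group and para to a large group, whereas in compound 1 it is ortho to a methoxy group and meta to a large group. Because of a number 13.5 percentage points higher from compound 2 to compound 1 (beyond the scatter) the expected step is a number 11.3 percentage points higher from compound 3 to compound 4 (beyond the scatter). Compound 4 is expected to give 48%, likely between 32% and 66%.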

Compound 4, a percentage reported as activity, at one concentration (the size of the read-out at that concentration, not a potency): 63%
Estimate against measurement, compound 4: 15 percentage points below; the measured number falls inside the stated range.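

In this assay, replacing a methoxy group with hydrogen on the core of compound 3 gave a number 26.3 percentage points higher from compound 3 to compound 4 (beyond the scatter). The change moves the number the same way on both cores, and the two step sizes cannot be told apart: the same change on two cores in this assay, a number 13.5 percentage points higher (beyond the scatter) from compound 2 to compound 1 and a number 26.3 percentage points higher (beyond the scatter) from compound 3 to compound 4, 12.8 percentage points apart, within the scatter of two such steps

Still, two pairs tested at one concentration do not show that the step would keep its direction or size on a further core, or at another place on the ring. The compounds shown leave open what groups other than hydrogen would do in place of the methoxy group. An amine or a longer ethoxy group there might give a similar number or a very different one.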